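A few compounds are considered here, and "the series" means these few. Any claim that something is new, unique, unknown or untested is made for them only; others in the source may bear on it.

Measured so far in an ADME assay on Vero cells (Chlorocebus sabaeus) for cytotoxicity, read by MTT assay, with a stated time of 72 h; a higher number here means a weaker inhibitor, a lower number a stronger inhibitor:

Compound 1 `O=C(c1ccncc1)N1N=C(c2cc3ccccc3o2)CC1c1ccccc1O` gives only a limit, > 195000 nM.
Compound 2 `O=C(O)c1ccccc1C1CC(c2cc3ccccc3o2)=NN1C(=O)c1ccncc1` gives only a limit, > 170000 nM.
Compound 3 `O=C(c1ccncc1)N1N=C(c2cc3ccccc3o2)CC1c1ccc(O)cc1` gives only a limit, > 200000 nM.

Compound 2 therefore stands at no number at all in this assay, only at the limit of > 170000 nM in this assay, at which 1 of the 3 values shown sits, and its two neighbours likewise sit at the limit of > 195000 nM in this assay, at which 1 of the 3 values shown sits, and (the limit of > 200000 nM in this assay, at which 1 of the 3 values shown sits). The step to the new compound 4 `O=C(c1ccncc1)N1N=C(c2cc3ccccc3o2)CC1c1ccc(Cl)cc1` is 4-chlorophenyl in place of 2-carboxyphenyl on a saturated ring carbon. Going by the values given here, two measured steps touch the same ring carbon: a step that the two limits leave unreadable from compound 2 to compound 3 and a step that the two limits leave unreadable from compound 1 to compound 3, and a third, a step that the two limits leave unreadable from compound 1 to compound 2, swaps the same pair of groups in another way. None of the three can be read in size, since each compound reaches the limit of this assay. Nothing measured here points to a readable step in either direction, so no change beyond the scatter is expected, and the most likely outcome for compound 4 is again a limit. The estimated step that the limit leaves unreadable from compound 2 to compound 4 is close to none. Compound 4 is expected to give about 200000 nM, between 100000 nM and 400000 nM.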

Compound 4, half-maximal inhibitory concentration: > 220000 nM
Compound 4 gave a limit, no number; the forecaster's own chance of this, stated with the estimate: 85%; middle value at least 1.1-fold (0.04 log units) from the limit.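

Compound 4 gives only a limit in this assay, just as compound 1, compound 2 and compound 3 do, so none of the steps to compound 4 can be read. The compounds shown leave open whether these four differ at all in this assay.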